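The source may hold more compounds than are shown below. What is called first, only, known or untested is meant among the compounds shown, and "the series" means these compounds.

Compound 3 `CC(C)(N)CC(=O)N[C@@H]1CCc2ccccc2N(Cc2ccc(-c3ccccc3S(N)(=O)=O)cc2)C1=O` gives 3 uM in a functional assay (Pituitary gland cell) with Rattus norvegicus as the target (on this read-out higher numbers stand for an effect only at larger amounts of compound and lower numbers for an effect already at smaller amounts), and stands second highest of the three numbers measured. Compound 1 `CC(C)(N)CC(=O)N[C@@H]1CCc2ccccc2N(Cc2ccc(-c3ccccc3S(=O)(=O)NC(C)(C)C)cc2)C1=O` gives 4 uM in this assay, and a 1.3-fold lower number from compound 1 to compound 3 (0.12 log units; within the scatter). Compound 2 `CC(C)(N)CC(=O)N[C@@H]1CCc2ccccc2N(Cc2ccc(-c3ccccc3-c3nnnn3Cc3ccccc3)cc2)C1=O` gives 0.7 uM in this assay, and a 4.3-fold higher number from compound 2 to compound 3 (0.63 log units; beyond the scatter). Compound 4 `CC(C)(N)CC(=O)N[C@@H]1CCc2ccccc2N(Cc2ccc(-c3ccccc3-c3nnnn3CC(=O)O)cc2)C1=O` has not yet been measured; it differs from compound 3 in that (1-(carboxymethyl)-1H-tetrazol-5-yl in place of sulfamoyl on an aromatic carbon). The closest guide is the step between compound 2 and compound 3, where a 4.3-fold higher number from compound 2 to compound 3 (0.63 log units; beyond the scatter) in the opposite direction; the tetrazole here carries a different group, so the size is uncertain. A modest lowering of the number is therefore expected, a 2.0-fold lower number from compound 3 to compound 4 (0.30 log units; within the scatter), and compound 4 is estimated at 1.5 uM in this assay, within a range from 0.4 uM to 5 uM.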

Compound 4, concentration for half-maximal effect: 1 uM
Compound 4: middle estimate off by 1.5-fold (0.18 log units), on the high side; the range from low to high includes it.
By their numbers in this assay, from the lowest: compounds 2 and 4 (each within the scatter of the next); then compounds 3 and 1 (each within the scatter of the next).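

In this assay, a 1-substituted tetrazole at this position still gives lower numbers than either sulfonamide when the substituent is carboxymethyl rather than benzyl (a 3.0-fold lower number from compound 3 to compound 4 (0.48 log units; beyond the scatter); a 4.0-fold lower number from compound 1 to compound 4 (0.60 log units; beyond the scatter)). Carboxy in place of phenyl on that chain makes no clear difference (a 1.4-fold higher number from compound 2 to compound 4 (0.15 log units; within the scatter)), so the phenyl ring is not required for the lower number in this set. Nothing available explains these results. As far as these compounds go, it remains open whether an amine in place of the carboxy group, or a longer chain carrying it, would keep the number this low.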